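This account rests on a few compounds, and the source may have more. Where it says the series, first, only, none or still open, it means among the compounds named here.

Measured in a functional assay on NCI-H460 cells (Homo sapiens) for inhibition, read by MTT assay, with a stated time of 72 h; a lower number here means a stronger inhibitor, a higher number a weaker inhibitor:
compound 1 `Cc1nc(-c2ccccc2F)c(C(=O)N2CCN(c3cc(Cl)cc(Cl)c3)CC2)o1`: 165 nM
compound 2 `COc1cc(OC)cc(N2CCN(C(=O)c3oc(C)nc3-c3ccccc3F)CC2)c1`: 42 nM
compound 3 `COc1cc(OC)cc(N2CCN(C(=O)c3oc(C)nc3-c3ccc(F)cc3)CC2)c1`: 68 nM

Compound 1 has the highest number of the three, which makes it the weakest inhibitor here, and both other compounds lie beyond the scatter from it. Compound 4 `Cc1nc(-c2cccc(F)c2)c(C(=O)N2CCN(c3cc(Cl)cc(Cl)c3)CC2)o1` has not been measured yet. It keeps the 3,5-dichlorophenyl group of compound 1 and alters only the fluorophenyl group: 3-fluorophenyl in place of 2-fluorophenyl on an aromatic carbon. In short, 3-fluorophenyl stands in place of 2-fluorophenyl on an aromatic carbon.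

Two measured steps are available. The first, a 3.9-fold lower number from compound 1 to compound 2 (0.59 log units; beyond the scatter), swaps 3,5-dichlorophenyl for 3,5-dimethoxyphenyl, a different place from the one changing now, so it offers little guidance. The closer guide is a 1.6-fold higher number from compound 2 to compound 3 (0.21 log units; within the scatter), where 4-fluorophenyl replaces 2-fluorophenyl. It is only a partial guide, since it ends in 4-fluorophenyl rather than 3-fluorophenyl and was measured on compounds carrying 3,5-dimethoxyphenyl. Within the data shown here, no compound with 3-fluorophenyl has been measured so far.

On that basis, no change beyond the scatter is expected in this assay. The expected step is a 1.1-fold lower number from compound 1 to compound 4 (0.04 log units; within the scatter). For compound 4 the estimate is 150 nM, with an expected range of 70 nM to 330 nM.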

Compound 4, half-maximal inhibitory concentration: 221 nM
The estimate for compound 4 lay 1.5-fold (0.17 log units) below the measured number; measured number inside the range.
By their numbers in this assay, from the lowest: compounds 2 and 3 (each within the scatter of the next); then compounds 1 and 4 (each within the scatter of the next).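

In this assay, the position on the aromatic carbon next to the ring nitrogen now has a second fluorophenyl variant, and 3-fluorophenyl in place of 2-fluorophenyl gives a 1.3-fold higher number from compound 1 to compound 4 (0.13 log units; within the scatter), so this change leaves no readable difference on the 3,5-dichlorophenyl series. Among these compounds, the earlier step at this position, a 1.6-fold higher number from compound 2 to compound 3 (0.21 log units; within the scatter), was also within the scatter, but it involved 4-fluorophenyl and carried 3,5-dimethoxyphenyl; taken together, the two steps show that neither of these changes in the fluorophenyl group, each read with its own partner group, moves the number measurably, while the one step beyond the scatter so far lies at the other end of the molecule. No measurement is available that explains why these fluorophenyl groups give such similar numbers.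

Among the compounds shown here, whether 3-fluorophenyl would also match 2-fluorophenyl when paired with 3,5-dimethoxyphenyl remains open, since each step covers only one partner group. Also open, as far as these compounds go, is whether this position tolerates something other than a fluorine on the phenyl ring, such as an amine or a carboxylic acid, or a plain phenyl with no fluorine at all.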